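Diisopropylamino in place of acetoxy: working notes

A few compounds are considered here, and "the series" means these few. Any claim that something is new, unique, unknown or untested is made for them only; others in the source may bear on it.

In a functional assay on A549 cells (Homo sapiens) for antiproliferative activity, read by MTT assay, with a stated time of 48 h (on this read-out lower numbers stand for stronger inhibition and higher numbers for weaker inhibition), compound 1 `CC(=O)OC/C1=C/C[C@](C)(CCC=C(C)C)/C=C/[C@@H](OC(=O)C=C(C)C)[C@](C)(O)/C=C/C1=O` gives 2950 nM, the lowest of the three numbers and beyond the scatter of the other two. Compound 2 `CC(=O)OC/C1=C/C[C@](C)(CCC=C(C)C)/C=C/[C@@H](OC(=O)C=C(C)C)[C@](C)(OC(C)=O)/C=C/C1=O` gives 15100 nM, and compound 3 `CO[C@]1(C)/C=C/C(=O)/C(CO)=C\C[C@](C)(CCC=C(C)C)/C=C/[C@H]1OC(=O)C=C(C)C` gives 14400 nM. Compound 4 `CC(C)=CCC[C@]1(C)/C=C/[C@@H](OC(=O)C=C(C)C)[C@](C)(O)/C=C/C(=O)/C(CN(C(C)C)C(C)C)=C\C1` is unmeasured. Its change from the core of compound 1 is diisopropylamino in place of acetoxy on a saturated chain carbon bound to a double-bonded ring carbon, in words diisopropylamino in place of acetoxy on a saturated chain carbon bound to a double-bonded ring carbon. For the measured compounds named here, no measured step isolates this place. Going by the values given here, the only measured step, a 5.1-fold higher number from compound 1 to compound 2 (0.71 log units; beyond the scatter), is modest and lies elsewhere in the molecule. Taking that step as a rough guide, the expected change is a 2.4-fold higher number from compound 1 to compound 4 (0.38 log units; beyond the scatter), a modest rise with wide uncertainty. For compound 4 the estimated value is 7000 nM, with an expected range of 2000 nM to 22000 nM.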

Compound 4, half-maximal inhibitory concentration: 650 nM
Beside the measured number, compound 4's estimate is 11-fold (1.03 log units) above it, and the stated range ends above it.
By their numbers in this assay, from the lowest: compound 4; then compound 1; then compounds 3 and 2 (each within the scatter of the next).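

This place on the core of compound 1 responds to substitution: in this assay, diisopropylamino in place of acetoxy gives a 4.5-fold lower number from compound 1 to compound 4 (0.66 log units; beyond the scatter). For the compounds shown here, the earlier measured step, a 5.1-fold higher number from compound 1 to compound 2 (0.71 log units; beyond the scatter), lay elsewhere in the molecule and ran in the opposite direction, so a lower number had not yet been seen from compound 1. Nothing at hand accounts for this step.

This place rests on a single pair. From the compounds shown here alone, whether dimethylamino or morpholine in place of acetoxy would also lower the number remains open.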